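Shortening the selenocyanate tether: compound 2 to compound 3

This account rests on a few compounds, and the source may have more. Where it says the series, first, only, none or still open, it means among the compounds named here.

Measured so far:
compound 1 `Cc1nc(N(C)c2ccc([Se]C#N)c(Cl)c2)c2ccccc2n1`: 11 nM
compound 2 `COc1ccc(N(C)c2nc(C)nc3ccccc23)cc1OCCCCC[Se]C#N`: 3560 nM

In a functional assay on RKO cells (Homo sapiens) for inhibition, read by MTT assay, with a stated time of 48 h (a lower number here means a stronger inhibitor, a higher number a weaker inhibitor), compound 1 gives 11 nM. Among the compounds with values here, in the same assay compound 2 gives 3560 nM, the highest of the two numbers; its only neighbour is compound 1, and the gap between them lies far beyond the scatter. Within the data shown here, no single-point step between measured compounds is available, so the pair shows only that the two values differ.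

Compound 3 `COc1ccc(N(C)c2nc(C)nc3ccccc23)cc1[Se]C#N` is not yet measured. Against compound 2 the change is a group of 3 heavy atoms (1 carbon, 1 nitrogen, 1 selenium; no ring) in place of a group of 9 heavy atoms (6 carbon, 1 nitrogen, 1 oxygen, 1 selenium; no ring), on an aromatic carbon The entering group sits on an aromatic carbon, ortho to a methoxy group and meta to a large group, so compound 3 carries the selenocyanate as compound 1 does, though compound 1 has a chloro group where compound 3 has the methoxy.

A large downward step is expected in this assay, because compound 1 with the same group on an aromatic carbon gives 11 nM. The expected step of an 89-fold lower number from compound 2 to compound 3 (1.95 log units; beyond the scatter) is well beyond the scatter. Compound 3 is estimated at 40 nM, with a range from 8 nM to 250 nM.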

Compound 3, half-maximal inhibitory concentration: 47 nM
Compound 3: middle estimate off by 1.2-fold (0.07 log units), on the low side, and the stated range covers the measured number.
By their numbers in this assay, from the lowest: compound 1; then compound 3; then compound 2.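

In this assay, removing the oxy-linked chain and setting the selenocyanate directly on the aromatic carbon gives a 76-fold lower number from compound 2 to compound 3 (1.88 log units; beyond the scatter), so a long tether is not required at this position, ortho to a methoxy group and meta to a large group, and compound 3 reaches 47 nM without it. Both sides of the step carry the selenocyanate, which means the step reads as a change in how that group is attached to the ring and not as the gain or loss of the group itself. No measurement shown here gives a reason for the size of this step.

Only the two extremes of the tether are shown, so it remains open whether the number climbs gradually or abruptly with length, and a short ethoxy or propoxy chain ending in selenocyanate would separate these two readings. Also open, from the compounds shown here alone, is how much of the value at this aromatic carbon depends on the selenium, which a thiocyanate or a plain nitrile in the same place would test.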